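Cyclopropylsulfonyl to tolylsulfonyl on the amide-bearing anisole

The compounds below may be only part of what the source reports. "The series", "measured", "known", "first", "only" and "open" are said of these compounds alone.

Measured so far in a functional assay on HCT-116 cells (Homo sapiens) for antiproliferative activity, read by MTT assay, with a stated time of 72 h; a higher number here means a weaker inhibitor, a lower number a stronger inhibitor:
Compound 1 `COc1c(NS(=O)(=O)C2CC2)cc(-c2ccc3nc(NC(C)=O)nn3c2)cc1C(N)=O` gives 36300 nM.
Compound 2 `COc1c(NS(=O)(=O)c2ccc(F)cc2)cc(-c2ccc3nc(NC(=O)C4CC4)sc3n2)cc1C(N)=O` gives 2500 nM.
Compound 3 `COc1c(NS(=O)(=O)c2ccc(F)cc2)cc(-c2ccc3nc(NC(C)=O)sc3n2)cc1C(N)=O` gives 4250 nM.

Compound 1 stands with the highest of the three numbers; compound 3 sits nearest to it and compound 2 furthest, both gaps beyond the scatter. Compound 4 `COc1c(NS(=O)(=O)c2ccc(C)cc2)cc(-c2ccc3nc(NC(C)=O)nn3c2)cc1C(N)=O` keeps the core of compound 1 and changes only the sulfonamide: 4-methylphenyl in place of cyclopropyl on a sulfonyl sulfur. Going by the values given here, none of the measured steps touches this position. Among the compounds with values here, the only single-point step, a 1.7-fold higher number from compound 2 to compound 3 (0.23 log units; within the scatter), concerns the acyl group on the amide nitrogen and lies within the scatter, so it says nothing about the sulfonyl substituent. Compounds 2 and 3 do carry an arylsulfonyl group and give lower numbers than compound 1, but they differ from it in the core as well, so their values cannot be read as a step for this change. The size of a 3.0-fold lower number from compound 1 to compound 4 (0.48 log units; beyond the scatter) is therefore expected to be modest and uncertain, leaning toward a lower number. For compound 4 the estimate in this assay is 12000 nM, within a range from 3000 nM to 45000 nM.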

Compound 4, half-maximal inhibitory concentration: 27300 nM
For compound 4 the middle estimate is 2.3-fold (0.36 log units) below the measured one; low and high end bracket the measured number.
By their numbers in this assay, from the lowest: compounds 2 and 3 (each within the scatter of the next); then compounds 4 and 1 (each within the scatter of the next).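

Going by these compounds alone, this is the first direct reading at the sulfonyl sulfur, where none of the earlier steps reached. In this assay the step for 4-methylphenyl in place of cyclopropyl, on the shared core, is a 1.3-fold lower number from compound 1 to compound 4 (0.12 log units; within the scatter) and so shows no change that can be told from scatter. Within the data shown here, an aromatic carbon ring of 7 heavy atoms thus reads the same here as a three-membered carbon ring of 3 heavy atoms, and nothing measured so far offers an explanation for this result.

The compounds shown leave open whether an amine, a carboxylic acid or a longer alkyl chain on the sulfonyl sulfur would move the number on this core. They also leave open whether this same change would read alike on the core of compound 3.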